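A few compounds are considered here, and "the series" means these few. Any claim that something is new, unique, unknown or untested is made for them only; others in the source may bear on it.

Compound 1 `CC1OC(n2c(=O)n(C)c3c(O)nc(N)nc32)[C@H](O)[C@@H]1O`: 0%
Compound 2 `Cn1c(=O)n2c3c1c(=O)nc(N)n3CC1OC2[C@H](O)[C@@H]1O`: 9%
Compound 3 `CC1(C)O[C@@H]2[C@H](O1)[C@@H](CO)O[C@H]2n1c(=O)n(C/C=C/c2ccccc2)c2c(O)nc(N)nc21`: 16%

Of the compounds shown here, three have so far been measured in a functional assay on the whole organism (B cells) with Mus musculus as the target; a higher number here means a larger maximal response, a lower number a smaller maximal response. Compound 1 gives 0% and sits at the bottom of the three numbers. Its nearest neighbour is compound 2, which gives 9%, a gap that stays within the usual scatter of this assay, so the two cannot be told apart. Compound 3 gives 16%, and this gap to compound 1 lies beyond the scatter.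

Compound 4 `Cn1c(=O)n(C2OC(CI)[C@@H](O)[C@H]2O)c2nc(N)nc(O)c21` has not been measured. It differs from compound 1 in one place: iodo in place of hydrogen on a saturated chain carbon bound to a saturated ring carbon. For the measured compounds named here, no pair of measured compounds differs in a single place, so there is no measured step to lean on. The change is a single heavy atom on a saturated chain carbon, and compound 1 starts at the floor of the response range. A step from compound 1 to compound 4 of a number 5 percentage points higher from compound 1 to compound 4 (within the scatter) is expected in this assay, which would be within the scatter. Compound 4 is therefore expected to give about 5% in this assay, within a range of 0% to 20%.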

Compound 4, largest response reached (reported as maximal response), in percent of the reference or control that the assay uses: 32%
The estimate for compound 4 lay 27 percentage points below the measured number; measured number above the stated range.
By their numbers in this assay, from the lowest: compounds 1, 2 and 3 (each within the scatter of the next, the first and the last beyond it); then compound 4.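

In this assay, iodo in place of hydrogen on a saturated chain carbon bound to a saturated ring carbon gives a number 32 percentage points higher from compound 1 to compound 4 (beyond the scatter). For the compounds shown here, this is the first single-place step, and it shows that this position is not silent: one heavy atom here is enough to lift the response clear of the floor on which compound 1 sits. Nothing measured on these compounds accounts for the rise.

From the compounds shown here alone, whether the rise is specific to iodo stays open, as a chloro, a bromo, an amine or a longer chain on the same carbon would be needed to show how far it extends beyond this one group. Going by these compounds, it also remains open whether the same change would raise the response on any core other than that of compound 1.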